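A few compounds are considered here, and "the series" means these few. Any claim that something is new, unique, unknown or untested is made for them only; others in the source may bear on it.

Compound 2 `Nc1nn(C(=O)Nc2ccc(Cc3ccccc3)cc2)c2ccc(Cl)cc12` is the chlorinated congener of compound 1 `Nc1nn(C(=O)Nc2ccc(Cc3ccccc3)cc2)c2ccccc12`. In a functional assay on MOLT-4 cells (Homo sapiens) for antiproliferative activity, read by sulforhodamine B assay, with a stated time of 48 h (a higher number here means a weaker inhibitor of growth, a lower number a stronger inhibitor of growth), compound 1 gives 20400 nM, and in the same assay compound 2 gives 55300 nM, which is the higher of the two numbers shown; the step of a 2.7-fold higher number from compound 1 to compound 2 (0.43 log units; beyond the scatter) is a modest one. Compound 3 `Nc1ccc2c(c1)c(N)nn2C(=O)Nc1ccc(Cc2ccccc2)cc1` differs from compound 2 by amino in place of chloro on an aromatic carbon. Among the measured compounds shown here, only one measured step touches this position, and it was modest, so the site tolerates a change without a large swing in either direction. For the measured compounds named here, an amino group restores a hydrogen-bond donor and acceptor that chloro lacks; no measured pair tests that directly. Compound 3 is therefore expected to land near compound 1 or between the two, and the estimated step of a 1.8-fold lower number from compound 2 to compound 3 (0.27 log units; within the scatter) would be a mild fall in the number. For compound 3 the estimate in this assay is 30000 nM, within a range from 10000 nM to 90000 nM.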

Compound 3, concentration for total growth inhibition: 24300 nM
Beside the measured number, compound 3's estimate is 1.2-fold (0.09 log units) above it, within the range that was stated.
By their numbers in this assay, from the lowest: compounds 1 and 3 (each within the scatter of the next); then compound 2.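

In this assay, the change from chloro to amino gives a 2.3-fold lower number from compound 2 to compound 3 (0.36 log units; beyond the scatter), so the number at this position depends on which group occupies it. Replacing hydrogen with amino gives a 1.2-fold higher number from compound 1 to compound 3 (0.08 log units; within the scatter), which shows that this site can carry a substituent without a shift beyond the scatter, and that the rise seen with chloro does not follow from substitution alone. Nothing available explains why the two groups differ in this way.

The three compounds leave open whether the rise is particular to chloro or would also appear with fluoro, bromo, methyl or methoxy on the same aromatic carbon. They also leave open whether an acetamide or a dimethylamino group there would stay as close to the unsubstituted compound as amino does.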